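This account rests on a few compounds, and the source may have more. Where it says the series, first, only, none or still open, it means among the compounds named here.

Measured compounds:
- Compound 1, `O=C(CSc1nnc(-c2ccncc2)o1)N/N=C/c1ccc([N+](=O)[O-])cc1`: 17900 nM
- Compound 2, `COc1cccc(/C=N/NC(=O)CSc2nnc(-c3ccncc3)o2)c1`: 9170 nM
- Compound 3, `O=C(CSc1nnc(-c2ccncc2)o1)N/N=C/c1cc(Cl)ccc1O`: 3970 nM

All three share one core and differ only in the aryl group on the carbon with a double bond to nitrogen. In a functional assay on HepG2 cells (Homo sapiens) for cytotoxicity, read by MTT assay, with a stated time of 48 h (a higher number here means a weaker inhibitor, a lower number a stronger inhibitor), compound 1 gives the highest number of the three, that is, it is the weakest inhibitor here. The step of a 2.0-fold lower number from compound 1 to compound 2 (0.29 log units; within the scatter) stays within the scatter, while a 4.5-fold lower number from compound 1 to compound 3 (0.65 log units; beyond the scatter) and a 2.3-fold lower number from compound 2 to compound 3 (0.36 log units; beyond the scatter) go beyond it, though only modestly.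

Compound 4, `COc1cc(/C=N/NC(=O)CSc2nnc(-c3ccncc3)o2)ccc1O`, is not yet measured. It differs from compound 1 as follows:
4-hydroxy-3-methoxyphenyl in place of 4-nitrophenyl on a carbon with a double bond to nitrogen

The two steps from compound 1 bear on this change, since both also replace the 4-nitrophenyl with an oxygen-bearing aryl group; one was within the scatter, the other modest. Compound 3 carries a hydroxyl like compound 4 and gave the largest drop, so compound 4 is expected to give a modestly lower number than compound 1, roughly a 3.0-fold lower number from compound 1 to compound 4 (0.47 log units; beyond the scatter). The estimate for compound 4 in this assay is 6000 nM, with a range from 2500 nM to 15000 nM.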

Compound 4, half-maximal inhibitory concentration: 2920 nM
Compound 4: middle estimate off by 2.1-fold (0.31 log units), on the high side; the measured number falls inside the stated range.
By their numbers in this assay, from the lowest: compounds 4 and 3 (each within the scatter of the next); then compounds 2 and 1 (each within the scatter of the next).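

For the compounds shown here, putting hydroxy in place of hydrogen on an aromatic carbon gives a 3.1-fold lower number from compound 2 to compound 4 (0.50 log units; beyond the scatter) in this assay and is the first step here that changes one small group on an otherwise unchanged aryl ring. Going by these compounds alone, the full change from 4-nitrophenyl to 4-hydroxy-3-methoxyphenyl gives a 6.1-fold lower number from compound 1 to compound 4 (0.79 log units; beyond the scatter) and is the largest step so far, while a 1.4-fold lower number from compound 3 to compound 4 (0.13 log units; within the scatter) shows that these two hydroxy-bearing aryl groups cannot be told apart in this assay. Nothing available explains why a hydroxy-bearing aryl group goes with these lower numbers.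

From the compounds shown here alone, whether the hydroxy acts alone or needs the methoxy stays open, and a plain 4-hydroxyphenyl group would separate the two. Going by these compounds, how an aryl group carrying an amine or a carboxylic acid would compare at this place also stays open.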